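The source may report more compounds than this note shows. Statements on the series, on what has been measured and on what is new or still open speak of the compounds shown alone.

Measured compounds in the set:

Compound 1, `COC(=O)c1cc(-c2cccc(NC(=O)c3ccc(/C=C/C(=O)c4cc(OC)c(OC)c(OC)c4)cc3)c2)on1`: in an ADME assay on Vero cells (Chlorocebus sabaeus) for cytotoxicity, read by MTT assay, with a stated time of 72 h (on this read-out lower numbers stand for higher toxicity in this test and higher numbers for lower toxicity in this test), compound 1 gives > 50 ug/mL, which is a limit of the assay and not a number.
Compound 2, `COC(=O)c1cc(-c2cccc(NC(=O)c3ccc(/C=C/C(=O)c4cccc(C(F)(F)F)c4)cc3)c2)on1`: in this assay compound 2 gives > 20 ug/mL, again a limit rather than a number.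
Compound 3, `COC(=O)c1cc(-c2cccc(NC(=O)c3ccc(/C=C/C(=O)c4ccccc4Br)cc3)c2)on1`: in this assay compound 3 gives > 40 ug/mL, also a limit.

Compound 3 therefore stands on a limit only, and the other two values shown are limits as well, so no order among the three compounds can be read. The steps a step that the two limits leave unreadable from compound 1 to compound 2, a step that the two limits leave unreadable from compound 1 to compound 3 and a step that the two limits leave unreadable from compound 2 to compound 3 are all unreadable because of the limit of > 20 ug/mL in this assay, at which 1 of the 3 values shown sits, the limit of > 40 ug/mL in this assay, at which 1 of the 3 values shown sits, and (the limit of > 50 ug/mL in this assay, at which 1 of the 3 values shown sits).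

Compound 4, `COC(=O)c1cc(-c2cccc(NC(=O)c3ccc(/C=C/C(=O)c4cccc([N+](=O)[O-])c4)cc3)c2)on1`, is the next member to be measured. It differs from compound 3 by 3-nitrophenyl in place of 2-bromophenyl on a carbonyl carbon. The change sits on a carbonyl carbon whose other neighbours are a double-bonded chain carbon, the same place varied in the three measured steps above, none of which gives a readable size. No direction or size can thus be drawn from the measured steps, and the step that the limit leaves unreadable from compound 3 to compound 4 is expected to stay within scatter or remain unreadable. Compound 4 is estimated at 50 ug/mL, with a range from 20 ug/mL to 100 ug/mL, most likely reported as a limit again.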

Compound 4, half-maximal cytotoxic concentration: > 40 ug/mL
Compound 4: a limit, no number; the forecaster's own chance of this, stated with the estimate: 80%; the middle value is on the limit's open side.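

No new step can be read: compound 4 sits on a limit, as do compound 1, compound 2 and compound 3, so its steps from all three stay unreadable, with compound 3 and compound 4 sharing one limit: the limit of > 40 ug/mL in this assay, at which 2 of the 4 values shown sit.

The compounds shown leave open how the groups on the carbonyl carbon compare in this assay, where none of the four has a numerical value.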